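This account rests on a few compounds, and the source may have more. Where it says the series, first, only, none or still open, it means among the compounds named here.

Measured compounds:
compound 1 `CCc1cccc2c(OC)c(-c3occ(C)c3C(=S)OC)ccc12`, 5.8 ug/mL;
compound 2 `CCOCc1c(C)coc1-c1ccc2c(CC)cccc2c1OC`, 9.1 ug/mL;
compound 3 `CCc1cccc2c(OC)c(-c3occ(C)c3CBr)ccc12`, 4.6 ug/mL.

In a functional assay on MDA-MB-231 cells (Homo sapiens) for cytotoxicity, read by MTT assay, with a stated time of 72 h (a lower number here means that less compound is needed, a higher number that more compound is needed for the effect), compound 3 shows the smallest number of the three, yet the gaps are slight: a 1.3-fold lower number from compound 1 to compound 3 (0.10 log units; within the scatter) and a 2.0-fold lower number from compound 2 to compound 3 (0.30 log units; within the scatter), both within the scatter, so the three compounds cannot really be told apart on this assay. The shared core is held constant throughout, and only the group on the saturated chain carbon bound to an aromatic carbon is varied.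

Compound 4 `CCc1cccc2c(OC)c(-c3occ(C)c3COC(=O)CCN(CC)CC)ccc12` continues at the same position: ((2-(diethylamino)ethyl)carbonyl)oxy in place of bromo on a saturated chain carbon bound to an aromatic carbon. For the measured compounds named here, the steps that bear on this are those that already exchange groups at that position, a 2.0-fold lower number from compound 2 to compound 3 (0.30 log units; within the scatter) and a 1.3-fold lower number from compound 1 to compound 3 (0.10 log units; within the scatter), and neither moved the number beyond the scatter. Going by the values given here, there is no measured step in which a group as large as the entering one, or one carrying a nitrogen, has been introduced, so the new ester is not directly covered by anything measured. The expectation is therefore a step of no more than about a 1.4-fold higher number from compound 3 to compound 4 (0.15 log units; within the scatter), with no firm direction. Compound 4 is thus estimated at 6.5 ug/mL, expected to fall between 2.8 ug/mL and 16 ug/mL in this assay.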

Compound 4, concentration for half-maximal effect: 1.7 ug/mL
Beside the measured number, compound 4's estimate is 3.8-fold (0.58 log units) above it; the whole stated range lies above it.
By their numbers in this assay, from the lowest: compound 4; then compounds 3, 1 and 2 (each within the scatter of the next).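

In this assay the saturated chain carbon bound to an aromatic carbon now shows what the earlier exchanges there did not, a change beyond the scatter: ((2-(diethylamino)ethyl)carbonyl)oxy in place of bromo gives a 2.7-fold lower number from compound 3 to compound 4 (0.43 log units; beyond the scatter) and (2-(diethylamino)ethyl)carbonyl in place of ethyl on the oxygen gives a 5.4-fold lower number from compound 2 to compound 4 (0.73 log units; beyond the scatter) as well. Both steps are modest, but they show that this position accepts a much larger group carrying a nitrogen and that the number falls rather than rises when it enters. No measurement shown here accounts for the fall, so the reason for it remains unknown.

The compounds shown do not separate the contribution of the diethylamino nitrogen from that of the ester carbonyl or of the chain that joins them. A simple amine on the same carbon, a carboxylic acid at the end of the chain, a longer chain without nitrogen, or an amide in place of the ester would be needed to tell these parts apart.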